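From carbonyl to sulfonyl on a shared core

The source may hold more compounds than are shown below. What is called first, only, known or untested is meant among the compounds shown, and "the series" means these compounds.

Measured so far:
compound 1 `Cc1cc(C#N)cc(C)c1Oc1nc(NC2CCC(NS(=O)(=O)c3cccc(C(F)(F)F)c3)CC2)nc2ccsc12` gives 6680 nM
compound 2 `Cc1cc(C#N)cc(C)c1Oc1nc(NC2CCC(NC(=O)c3ccc(Br)cc3)CC2)nc2ccsc12` gives 2850 nM
compound 3 `Cc1cc(C#N)cc(C)c1Oc1nc(NC2CCC(NC(=O)c3cccc(C(F)(F)F)c3)CC2)nc2ccsc12` gives 3240 nM

In an ADME assay on MT4 cells (Homo sapiens) for cytotoxicity, read by MTT assay, with a stated time of 5 days (on this read-out higher numbers stand for lower toxicity in this test and lower numbers for higher toxicity in this test), compound 3 reads 3240 nM and shares its place with compound 2, as the two lie within the scatter of each other. Compound 1 stands higher, at 6680 nM on the same scale.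

Compound 4 `Cc1cc(C#N)cc(C)c1Oc1nc(NC2CCC(NS(=O)(=O)c3ccc(F)cc3)CC2)nc2ccsc12` has not yet been measured. It carries (4-fluorophenyl)sulfonyl in place of (3-(trifluoromethyl)phenyl)carbonyl on an amine nitrogen. Counted up, the change is (4-fluorophenyl)sulfonyl in place of (3-(trifluoromethyl)phenyl)carbonyl on an amine nitrogen and it has two parts, the substituted ring and the group that links it.

For the measured compounds named here, only one measured step changes the ring alone. That step is a 1.1-fold higher number from compound 2 to compound 3 (0.06 log units; within the scatter) and it stays within the scatter, so the ring part is expected to add little. Going by the values given here, no measured step isolates the linking group, but the values offer a hint. With the same 3-(trifluoromethyl)phenyl ring, compound 1 on a sulfonyl reads 6680 nM and compound 3 on a carbonyl reads 3240 nM in a single comparison. A higher number is therefore expected, and the estimated step is a 1.9-fold higher number from compound 3 to compound 4 (0.27 log units; within the scatter) in that direction. Compound 4 is estimated at 6000 nM with an expected range from 3000 nM to 12000 nM on this evidence.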

Compound 4, half-maximal cytotoxic concentration: 3530 nM
Compound 4: middle estimate off by 1.7-fold (0.23 log units), on the high side; measured number inside the range.
By their numbers in this assay, from the lowest: compounds 2, 3, 4 and 1 (each within the scatter of the next, the first and the last beyond it).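

In this assay, compound 4 carries a sulfonyl on the amine nitrogen, yet it does not separate from the two carbonyl compounds (a 1.1-fold higher number from compound 3 to compound 4 (0.04 log units; within the scatter); a 1.2-fold higher number from compound 2 to compound 4 (0.09 log units; within the scatter)), as both steps lie within the scatter, so a sulfonyl at this position does not by itself set a compound apart from them. Compound 1 and compound 4 share the sulfonyl and differ only in the ring attached to it, with 4-fluorophenyl in place of 3-(trifluoromethyl)phenyl, and this step also stays within the scatter (a 1.9-fold lower number from compound 1 to compound 4 (0.28 log units; within the scatter)), so changing the ring on the sulfonyl does not clearly separate the two compounds either. No evidence at hand explains why these numbers fall as they do.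

The ring and the linking group remain unseparated for the 4-fluorophenyl ring, and a (4-fluorophenyl)carbonyl group on the same nitrogen would be the direct partner of compound 4. Also open, on these data alone, is how far the number would move if the ring carried a carboxylic acid or an amine, or if a longer chain took the place of the ring.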